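This account rests on a few compounds, and the source may have more. Where it says the series, first, only, none or still open, it means among the compounds named here.

Of the compounds shown here, two have been measured in a functional assay on BCG823 cells (Homo sapiens) for inhibition, read by MTT assay, with a stated time of 72 h; on this read-out lower numbers stand for stronger inhibition and higher numbers for weaker inhibition. Compound 1 `CN(C(=O)NC(=O)c1cccc(C(F)(F)F)c1)c1nc(C(F)(F)F)c(C(=O)N/N=C/c2cccc(C(F)(F)F)c2)s1` carries a 3-(trifluoromethyl)phenyl group on a carbonyl carbon whose other neighbour is an amide-type nitrogen, and in this assay compound 1 gives 4.6 ug/mL. Compound 2 `CN(C(=O)NC(=O)c1c(F)cccc1F)c1nc(C(F)(F)F)c(C(=O)N/N=C/c2ccc(C(F)(F)F)cc2)s1` carries a 2,6-difluorophenyl group at that same carbonyl, and in this assay compound 2 gives 34.9 ug/mL, the higher of the two numbers, with compound 1 standing a good way below it, beyond the usual scatter of repeat measurements. The two compounds also differ elsewhere in the molecule, so these two values alone cannot show which change is responsible.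

Compound 3 `CN(C(=O)NC(=O)c1cccc(C(F)(F)F)c1)c1nc(C(F)(F)F)c(C(=O)N/N=C/c2ccc(C(F)(F)F)cc2)s1` has not yet been measured. Relative to compound 2 the change is 3-(trifluoromethyl)phenyl in place of 2,6-difluorophenyl on a carbonyl carbon, with the rest of the molecule unchanged. Compound 3 is expected to move downward, toward stronger inhibition, by a 3.5-fold lower number from compound 2 to compound 3 (0.54 log units; beyond the scatter), because compound 1 with the same 3-(trifluoromethyl)phenyl group on that carbonyl gives 4.6 ug/mL. Compound 3 is therefore estimated at 10 ug/mL, with a plausible range from 3 ug/mL to 35 ug/mL.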

Compound 3, half-maximal inhibitory concentration: 4.22 ug/mL
Compound 3: the middle estimate sits 2.4-fold (0.37 log units) above what was measured, and the stated range covers the measured number.
By their numbers in this assay, from the lowest: compounds 3 and 1 (each within the scatter of the next); then compound 2.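

In this assay the change at the carbonyl can now be read on its own: 3-(trifluoromethyl)phenyl in place of 2,6-difluorophenyl on a carbonyl carbon gives an 8.3-fold lower number from compound 2 to compound 3 (0.92 log units; beyond the scatter) with the rest of the molecule unchanged, so the group at this position clearly matters for the read-out. Within the data shown here, the other place behaves differently: 4-(trifluoromethyl)phenyl in place of 3-(trifluoromethyl)phenyl on a carbon with a double bond to nitrogen gives a 1.1-fold lower number from compound 1 to compound 3 (0.04 log units; within the scatter) and so, in this pair, the two groups cannot be told apart, which leaves the carbonyl change as the only single change here with a step beyond the scatter. Nothing measured here explains why the carbonyl change has this effect.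

Among these compounds, with only two groups compared on that carbonyl, it remains open whether the trifluoromethyl group or the absence of the two fluorines matters more, and a plain phenyl group or a ring-bound amine there would help separate the two. Also open, on these data alone, is whether the two groups on the carbon with a double bond to nitrogen would still match with 2,6-difluorophenyl on the carbonyl.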